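The source may report more compounds than this note shows. Statements on the series, on what has been measured and on what is new or still open speak of the compounds shown alone.

Three compounds sharing one core were measured in a functional assay on A549 cells (Homo sapiens) for inhibition, read by CCK-8 assay, with a stated time of 72 h, tested at 1 uM; on this read-out lower numbers stand for less inhibition of growth and higher numbers for more inhibition of growth at the one concentration tested. Compound 1 `CN(C)C(=O)c1cc2cnc(Nc3ccc(NC(=O)C4(C(=O)Nc5cccc(Br)c5)CC4)cc3)nc2n1C1CCCC1` gives 20.2% in this assay. Compound 2 `CN(C)C(=O)c1cc2cnc(Nc3ccc(NC(=O)C4(C(=O)Nc5ccc(O)cc5)CC4)cc3)nc2n1C1CCCC1` gives 93.6%, and compound 3 `COC(=O)c1cccc(NC(=O)C2(C(=O)Nc3ccc(Nc4ncc5cc(C(=O)N(C)C)n(C6CCCC6)c5n4)cc3)CC2)c1` gives 10.5%. Compound 3 thus stands lowest of the three numbers, though its gap to compound 1, a number 9.7 percentage points lower from compound 1 to compound 3 (within the scatter), lies within the scatter. The step of a number 73.4 percentage points higher from compound 1 to compound 2 (beyond the scatter) and the step of a number 83.1 percentage points lower from compound 2 to compound 3 (beyond the scatter) are the only large movements, and both involve the 4-hydroxyphenyl group.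

Compound 4 `CN(C)C(=O)c1cc2cnc(Nc3ccc(NC(=O)C4(C(=O)Nc5cccc(C#N)c5)CC4)cc3)nc2n1C1CCCC1` has not yet been measured. It differs from compound 3 as follows: cyano in place of methoxycarbonyl on an aromatic carbon. The measured step that bears most directly on this change is a number 9.7 percentage points lower from compound 1 to compound 3 (within the scatter), in which one group on the aromatic carbon gave way to another without any movement beyond the scatter. The large steps of a number 73.4 percentage points higher from compound 1 to compound 2 (beyond the scatter) and a number 83.1 percentage points lower from compound 2 to compound 3 (beyond the scatter) concern the 4-hydroxyphenyl group and do not bear on the present exchange. On this basis the step of a number 7.5 percentage points higher from compound 3 to compound 4 (within the scatter) is expected to stay within the scatter. Compound 4 is therefore estimated at 18% in this assay, with a range from 5% to 40%.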

Compound 4, percent growth inhibition at one concentration: 70.8%
Compound 4: the middle estimate sits 52.8 percentage points below what was measured; the measured number lies above the stated range.
By their numbers in this assay, from the lowest: compounds 3 and 1 (each within the scatter of the next); then compound 4; then compound 2.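

In this assay the group on this aromatic carbon, meta to a large group, proves decisive: cyano in place of methoxycarbonyl gives a number 60.3 percentage points higher from compound 3 to compound 4 (beyond the scatter) and cyano in place of bromo gives a number 50.6 percentage points higher from compound 1 to compound 4 (beyond the scatter) in a series where bromo and methoxycarbonyl had stayed within the scatter of each other. The earlier compounds shown here had therefore made this place look indifferent to the exchange, yet the nitrile shows that it is not, and high inhibition at the one concentration tested is no longer confined to the compound with the 4-hydroxyphenyl group. That group still holds a lead, though a reduced one, with 3-cyanophenyl in its place giving a number 22.8 percentage points lower from compound 2 to compound 4 (beyond the scatter) and no measurement here explaining why the nitrile departs so far from bromo and methoxycarbonyl.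

The compounds shown leave open whether the nitrile is a lone exception at this place or whether a group such as a primary amide, a carboxylic acid or an amine would also raise inhibition. They also leave open whether the nitrile would keep its effect on another carbon of the ring, and how the ranking would look across a range of concentrations.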